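The source may hold more compounds than are shown below. What is called first, only, known or untested is meant among the compounds shown, and "the series" means these compounds.

Compound 1 `COc1ccc(CN(C)c2nc(Cc3c(Cl)cccc3Cl)c(C)c(=O)[nH]2)cc1` and compound 2 `Cc1c(Cc2c(Cl)cccc2Cl)nc(N(C)Cc2ccc([N+](=O)[O-])cc2)[nH]c1=O` share one core, while compound 3 `COc1ccc(CN(C)c2nc(C(C)c3c(F)cccc3F)c(C)c(=O)[nH]2)cc1` carries a different core; the difference between the two cores is not broken down here. Among the measured compounds shown here, compound 4 `Cc1c(C(C)c2c(F)cccc2F)nc(N(C)Cc2ccc([N+](=O)[O-])cc2)[nH]c1=O` is the one compound of the set not yet measured. In an ADME assay on TZM cells (Homo sapiens) for cytotoxicity, read by WST assay, with a stated time of 2 days (on this read-out higher numbers stand for lower toxicity in this test and lower numbers for higher toxicity in this test), compound 1 gives 17900 nM, and compound 2 gives 19500 nM. The change between them is nitro in place of methoxy on an aromatic carbon, and it made a step of a 1.1-fold higher number from compound 1 to compound 2 (0.04 log units; within the scatter). In this assay compound 3 gives 88800 nM, the highest number of the three. Compound 4 is related to compound 3 by the same change, (nitro in place of methoxy on an aromatic carbon), placed as it was in the earlier pair. Because the earlier step of a 1.1-fold higher number from compound 1 to compound 2 (0.04 log units; within the scatter) stayed within the scatter, the step from compound 3 to compound 4 is expected to be of the same small size, a 1.1-fold higher number from compound 3 to compound 4 (0.03 log units; within the scatter). Compound 4 is therefore estimated to give about 95000 nM in this assay, with a range from 48000 nM to 190000 nM.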

Compound 4, half-maximal cytotoxic concentration: > 50000 nM
Compound 4 ended at the assay's limit; the forecaster's own chance of this, stated with the estimate: 10%; the middle value is on the limit's open side.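

In this assay compound 4 gives only a limit of the assay, not a number: the limit of > 50000 nM in this assay, at which 1 of the 4 values shown sits. The step from compound 3 to compound 4 cannot be read, so the data neither confirm nor rule out that nitro in place of methoxy stays as small on this core as on the core of compound 1, where it made a 1.1-fold higher number from compound 1 to compound 2 (0.04 log units; within the scatter); one small step on one core is all that this series shows of the change. What can be read, with the nitro group kept in both compounds, is 1-(2,6-difluorophenyl)ethyl in place of 2,6-dichlorobenzyl, which made an at least 2.5-fold higher number from compound 2 to compound 4 (0.40 log units; beyond the scatter).

The compounds shown leave open how far compound 4 lies from its limit, and whether the change would stay as small on a third core. They also leave open how an amine or a carboxylic acid in place of the methoxy or nitro group on the aromatic carbon would read in this assay.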